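The source may hold more compounds than are shown below. What is called first, only, known or untested is meant among the compounds shown, and "the series" means these compounds.

Working notes on the series. Compound 3 `Cn1c(=O)c(S(=O)(=O)c2ccc(F)cc2)cc2cnc(Nc3ccc4cc[nH]c4c3)nc21` stands highest of the three numbers in a functional assay on K562 cells (Homo sapiens) for inhibition, read by trypan blue exclusion, with a stated time of 72 h (a lower number here means a stronger inhibitor, a higher number a weaker inhibitor), at 10000 nM. Compound 2 `Cn1c(=O)c(S(=O)(=O)c2ccc(F)cc2)cc2cnc(Nc3cnc4[nH]ccc4c3)nc21` gives 750 nM in this assay, and compound 1 `Cc1ccc(S(=O)(=O)c2cc3cnc(Nc4ccc5[nH]ccc5c4)nc3n(C)c2=O)cc1` gives 750 nM. Among the measured compounds shown here, the only single-point step measured is a 13-fold higher number from compound 2 to compound 3 (1.12 log units; beyond the scatter). Compound 4 `Cn1c(=O)c(S(=O)(=O)c2ccc(F)cc2)cc2cnc(Nc3ccc4[nH]ccc4c3)nc21` differs from compound 3 by 1H-indol-5-yl in place of 1H-indol-6-yl on a nitrogen on an aromatic ring. For the measured compounds named here, no measured step bears on this change directly; compound 1 carries the same 1H-indol-5-yl group and shows the lower number of the set, which suggests compound 4 could move toward that value, though compound 1 and compound 4 also differ elsewhere, so the expectation stays wide. Compound 4 is therefore expected at 1500 nM (range 400 nM to 6000 nM), an estimated step of a 6.7-fold lower number from compound 3 to compound 4 (0.82 log units; beyond the scatter).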

Compound 4, half-maximal inhibitory concentration: 200 nM
Compound 4: the middle estimate sits 7.5-fold (0.88 log units) above what was measured; the measured number lies below the stated range.
By their numbers in this assay, from the lowest: compound 4; then compounds 1 and 2 (each within the scatter of the next); then compound 3.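

In this assay, 1H-indol-5-yl in place of 1H-indol-6-yl gives a 50-fold lower number from compound 3 to compound 4 (1.70 log units; beyond the scatter) with the same atoms joined differently, so the attachment point on the indole alone separates these two compounds. Against the group of compound 2, whose six-membered ring holds a hetero atom, the 1H-indol-5-yl group gives a 3.8-fold lower number from compound 2 to compound 4 (0.57 log units; beyond the scatter) as a modest gain. Fluoro in place of methyl on an aromatic carbon gives a 3.8-fold lower number from compound 1 to compound 4 (0.57 log units; beyond the scatter) as a similarly modest gain.

No evidence on the cause of these steps is available. Still open, on these data alone, is how chloro or methoxy in place of fluoro would behave with the 1H-indol-5-yl group.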